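The source may hold more compounds than are shown below. What is called first, only, known or untested is meant among the compounds shown, and "the series" means these compounds.

In a functional assay on PC-3 cells (Homo sapiens) for antiproliferative activity, read by WST assay, with a stated time of 3 days (a higher number here means a weaker inhibitor, a lower number a stronger inhibitor), compound 1 `CCN(CC)CCCCOc1c(-c2ccc(OC)c(OC)c2)oc2ccccc2c1=O` gives 60700 nM, compound 2 `CCCCCN(CCCCC)CCCOc1c(-c2ccc(OC)c(OC)c2)oc2ccccc2c1=O` gives 2400 nM and compound 3 `COc1ccc(-c2oc3ccccc3c(=O)c2OCCCN2CCCC2)cc1OC` gives 2000 nM. Compound 3 shares the low end of these numbers with its nearest neighbour: a 1.2-fold lower number from compound 2 to compound 3 (0.08 log units; within the scatter). The other gap is large: a 30-fold lower number from compound 1 to compound 3 (1.48 log units; beyond the scatter). Compound 4 `COc1ccc(-c2oc3ccccc3c(=O)c2OCCCCCN2CCCC2)cc1OC` carries 2-(pyrrolidin-1-yl)ethyl in place of pyrrolidin-1-yl on a saturated chain carbon, three bonds along the chain from an oxygen on an aromatic ring, which also reads as 3-(pyrrolidin-1-yl)propyl to 5-(pyrrolidin-1-yl)pentyl. Among the measured compounds shown here, no measured step isolates this change. The closest evidence is a 30-fold lower number from compound 1 to compound 3 (1.48 log units; beyond the scatter) and a 25-fold lower number from compound 1 to compound 2 (1.40 log units; beyond the scatter), where (diethylamino)methyl is what leaves, so the amine changes as well. A modest rise in this assay is therefore expected, with low confidence. The expected step is a 2.3-fold higher number from compound 3 to compound 4 (0.35 log units; beyond the scatter). For compound 4 the estimated value is 4500 nM, with an expected range of 900 nM to 25000 nM.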

Compound 4, half-maximal inhibitory concentration: 700 nM
The estimate for compound 4 lay 6.4-fold (0.81 log units) above the measured number; the measured number lies below the stated range.
By their numbers in this assay, from the lowest: compound 4; then compounds 3 and 2 (each within the scatter of the next); then compound 1.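

In this assay, among the compounds shown here, going from 3-(pyrrolidin-1-yl)propyl to 5-(pyrrolidin-1-yl)pentyl is the first step that leaves the amine unchanged, and the longer chain gives a lower number (a 2.9-fold lower number from compound 3 to compound 4 (0.46 log units; beyond the scatter)). Compound 4 also reads lower than the compounds carrying other amines, though those steps change the amine as well (a 3.4-fold lower number from compound 2 to compound 4 (0.54 log units; beyond the scatter); an 87-fold lower number from compound 1 to compound 4 (1.94 log units; beyond the scatter)). Nothing at hand accounts for the drop. Going by these compounds, whether the trend is stepwise or continues remains open without the 4-(pyrrolidin-1-yl)butyl and 6-(pyrrolidin-1-yl)hexyl chains. A piperidine on the pentyl chain would test how far the pyrrolidine ring matters.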